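The compounds below may be only part of what the source reports. "The series", "measured", "known", "first", "only" and "open" are said of these compounds alone.

The study covers three measured compounds and one that still awaits measurement, all tested in a functional assay on MCF7 cells (Homo sapiens) for inhibition, read by MTT assay, with a stated time of 72 h; on this read-out higher numbers stand for weaker inhibition and lower numbers for stronger inhibition. Compound 1 `Nc1ccn(C[C@H](O)[C@H]2OC(=O)C(OCc3ccccc3)=C2OCc2ccccc2)c(=O)n1` gives 7340 nM in this assay. Compound 2 `Nc1ccn(CCC2(N)OC(=O)C(OCc3ccccc3)=C2OCc2ccccc2)c(=O)n1` gives 32000 nM in this assay, and compound 3 `NC1(CCn2c(=O)[nH]c(=O)[nH]c2=O)OC(=O)C(OCc2ccccc2)=C1OCc1ccccc1` gives 84900 nM. Among the three measured compounds, compound 1 stands lowest, with compound 2 nearest to it and compound 3 furthest away. How the core of compound 1 differs from the core of compound 2 is not broken down here.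

Compound 2 and compound 3 differ in one place: a group of 9 heavy atoms (3 carbon, 3 nitrogen, 3 oxygen; one six-membered aromatic ring with 3 hetero atoms) in place of a group of 8 heavy atoms (4 carbon, 3 nitrogen, 1 oxygen; one six-membered aromatic ring with 2 hetero atoms), on a saturated chain carbon, two bonds along the chain from a saturated ring carbon. This change brought a 2.7-fold higher number from compound 2 to compound 3 (0.42 log units; beyond the scatter).

Compound 4 `O=C1O[C@H]([C@@H](O)Cn2c(=O)[nH]c(=O)[nH]c2=O)C(OCc2ccccc2)=C1OCc1ccccc1` has not yet been measured in this assay. It differs from compound 1 as follows: a group of 9 heavy atoms (3 carbon, 3 nitrogen, 3 oxygen; one six-membered aromatic ring with 3 hetero atoms) in place of a group of 8 heavy atoms (4 carbon, 3 nitrogen, 1 oxygen; one six-membered aromatic ring with 2 hetero atoms), on a saturated chain carbon, two bonds along the chain from an oxygen on a saturated carbon and a saturated ring carbon. Going by the values given here, this is the same kind of change as the one that separates compound 2 from compound 3, though not the same change, since in compound 1 the chain carbon that carries the group lies two bonds along the chain from an oxygen on a saturated carbon as well as from a saturated ring carbon, whereas in compound 2 it lies two bonds from a saturated ring carbon only. Among the compounds with values here, because the single earlier instance gave a 2.7-fold higher number from compound 2 to compound 3 (0.42 log units; beyond the scatter), the same direction is expected here. Resting on that one step alone, compound 4 is expected to show a 2.7-fold higher number from compound 1 to compound 4 (0.44 log units; beyond the scatter), giving an estimated 20000 nM, with a likely range from 8000 nM to 50000 nM.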

Compound 4, half-maximal inhibitory concentration: > 100000 nM
Compound 4 was reported as a limit; the forecaster's own chance of this, stated with the estimate: 5%; at least 5.0-fold (0.69 log units) between middle value and limit.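

In this assay compound 4 gives > 100000 nM, a limit of the assay and not a number. Putting the group of 9 heavy atoms in place of the group of 8 heavy atoms on the core of compound 1 brought an at least 13-fold higher number from compound 1 to compound 4 (1.13 log units; beyond the scatter), so the direction matched that of the earlier step, but the size did not carry over from one core to the other: the same change on two cores in this assay, a 2.7-fold higher number (0.42 log units; beyond the scatter) from compound 2 to compound 3 and an at least 13-fold higher number (1.13 log units; beyond the scatter) from compound 1 to compound 4, at least 5.1-fold (0.71 log units) apart, beyond the scatter of two such steps The true size of the new step stays unknown because it ends at a limit, and a single pair on each core cannot show which feature of the two cores sets the gap, or whether the size of this change depends on the core more generally in this series: the limit of > 100000 nM in this assay, at which 1 of the 4 values shown sits.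

The compounds shown leave open how this change would behave on a core with a longer chain leading to the aromatic ring, or with a carboxylic acid on that chain. They also leave open whether a core carrying an amine on the chain, in place of the oxygen on a saturated carbon, would follow compound 1 or compound 2 in the size of its step.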